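A Dichlorophenyl Swap at the Assay Limit

The source may report more compounds than this note shows. Statements on the series, on what has been measured and on what is new or still open speak of the compounds shown alone.

In a functional assay on SW-620 cells (Homo sapiens) (on this read-out higher numbers stand for weaker inhibition of growth and lower numbers for stronger inhibition of growth), compound 1 `N#Cc1ccc(/C=C/S(=O)(=O)Cc2ccc(Nc3ncnc4ccccc34)cc2)cc1` gives > 100000 nM, which is a limit of the assay and not a number. Compound 2 `O=S(=O)(/C=C/c1ccc(Br)cc1)Cc1ccc(Nc2ncnc3ccccc23)cc1` gives > 100000 nM, also a limit. Compound 3 `CC(C)(C)c1cc(/C=C/S(=O)(=O)Cc2ccc(Nc3ncnc4ccccc34)cc2)cc(C(C)(C)C)c1O` gives a true number, 9000 nM. The series therefore leans on (the limit of > 100000 nM in this assay, at which 2 of the 3 values shown sit).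

Compound 4 `O=S(=O)(/C=C/c1ccc(Cl)cc1Cl)Cc1ccc(Nc2ncnc3ccccc23)cc1` differs from compound 1 by 2,4-dichlorophenyl in place of 4-cyanophenyl on a double-bonded chain carbon bound to a double-bonded chain carbon. The closest measured change, a step that the two limits leave unreadable from compound 1 to compound 2, puts bromo in place of cyano and gives no size, so only a small shift towards stronger inhibition of growth is expected in this assay. The expected change is an at least 1.6-fold lower number from compound 1 to compound 4 (0.22 log units; that floor lies within the scatter). For compound 4 the estimated value is 60000 nM, with an expected range of 15000 nM to 100000 nM.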

Compound 4, concentration for 50% growth inhibition: 14000 nM
The estimate for compound 4 lay 4.3-fold (0.63 log units) above the measured number; the measured number lies below the stated range.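

This place, on a double-bonded chain carbon bound to a double-bonded chain carbon, can respond in this assay: changing the aromatic group alone moves a compound off the assay limit. 2,4-dichlorophenyl in place of 4-cyanophenyl gives an at least 7.1-fold lower number from compound 1 to compound 4 (0.85 log units; beyond the scatter), and in place of 4-bromophenyl it gives an at least 7.1-fold lower number from compound 2 to compound 4 (0.85 log units; beyond the scatter). Both sizes are floors, since each starts from a limit: the limit of > 100000 nM in this assay, at which 2 of the 4 values shown sit.

The compounds shown leave open whether 2-chlorophenyl or 4-chlorophenyl alone would do the same. Going by these compounds, how a 4-aminophenyl group would read here also remains open.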